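This account rests on a few compounds, and the source may have more. Where it says the series, first, only, none or still open, it means among the compounds named here.

Compounds measured in a functional assay on the whole organism for activation, with Mus musculus as the target; a lower number here means that less compound is needed, a higher number that more compound is needed for the effect:
compound 1, `CCCCCOc1nc(N)c2nc(O)n(Cc3ccccc3)c2n1`: 0.3 mg/kg
compound 2, `CCCCCSc1nc(N)c2nc(O)n(Cc3ccccc3)c2n1`: 1 mg/kg
compound 3, `CCCSc1nc(N)c2nc(O)n(Cc3ccccc3)c2n1`: 0.1 mg/kg

Compound 3 stands lowest of the three in this assay. Its nearest neighbour is compound 1, reached through a 3.0-fold lower number from compound 1 to compound 3 (0.48 log units; beyond the scatter), and the gap to compound 2 is wider, a 10-fold lower number from compound 2 to compound 3 (1.00 log units; beyond the scatter). Compound 1 and compound 2 differ in the same way that compound 3 and compound 4 will: a 3.3-fold higher number from compound 1 to compound 2 (0.52 log units; beyond the scatter).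

Compound 4, `CCCOc1nc(N)c2nc(O)n(Cc3ccccc3)c2n1`, is not yet measured. It differs from compound 3 by propoxy in place of propylsulfanyl on an aromatic carbon. For the measured compounds named here, two measured steps bear on it. The step from the pentyloxy to the pentylsulfanyl chain, a 3.3-fold higher number from compound 1 to compound 2 (0.52 log units; beyond the scatter), runs in the opposite direction to the change now made, so read backwards it points to a lower number for compound 4. The step of shortening the sulfanyl chain, a 10-fold lower number from compound 2 to compound 3 (1.00 log units; beyond the scatter), suggests that the shorter chain may also favour the oxygen series, giving a second route from compound 1 to compound 4 that points the same way. Compound 4 is therefore expected to show a modest lowering beyond the scatter, a 2.5-fold lower number from compound 3 to compound 4 (0.40 log units; beyond the scatter). The estimate for compound 4 in this assay is 0.04 mg/kg, with a range from 0.012 mg/kg to 0.13 mg/kg.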

Compound 4, minimum effective dose: 0.3 mg/kg
Compound 4: the middle estimate sits 7.5-fold (0.88 log units) below what was measured; the measured number lies above the stated range.
By their numbers in this assay, from the lowest: compound 3; then compounds 1 and 4 (each within the scatter of the next); then compound 2.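

In this assay, the effect of exchanging sulfur and oxygen on this aromatic carbon, between two ring nitrogen atoms, depends on the chain: with the propyl chain, propoxy in place of propylsulfanyl gives a 3.0-fold higher number from compound 3 to compound 4 (0.48 log units; beyond the scatter), whereas with the pentyl chain, the exchange in the opposite direction gave a 3.3-fold higher number from compound 1 to compound 2 (0.52 log units; beyond the scatter), so in both pairs the number rises on going to the other atom's less favoured partner rather than with one atom throughout. Shortening the chain therefore does not carry over from the sulfanyl compounds to the oxygen compounds, where it gives no change at the digits printed from compound 1 to compound 4 (within the scatter), and the linking atom and chain length cannot be read as independent contributions at this position: the same change on two cores in this assay, a 10-fold lower number (1.00 log units; beyond the scatter) from compound 2 to compound 3 and no change at the digits printed (within the scatter) from compound 1 to compound 4, 10-fold (1.00 log units) apart, beyond the scatter of two such steps. Propoxy in place of pentylsulfanyl gives a 3.3-fold lower number from compound 2 to compound 4 (0.52 log units; beyond the scatter), which leaves the propylsulfanyl chain of compound 3 with the lowest number of the four.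

The propyl and pentyl chains are the only lengths shown on either linking atom, so it remains open how a butoxy or butylsulfanyl chain would fall. From the compounds shown here alone, whether an amine on this carbon would follow either series also remains open.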